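A Nitro-for-Methyl Change Carried onto a Second Core

A few compounds are considered here, and "the series" means these few. Any claim that something is new, unique, unknown or untested is made for them only; others in the source may bear on it.

Three compounds have been measured in a functional assay on HepG2 cells (Homo sapiens) for inhibition, read by MTT assay, with a stated time of 72 h; on this read-out lower numbers stand for stronger inhibition and higher numbers for weaker inhibition:

compound 1, `COc1cc(O)cc(O)c1C(=O)/C=C/c1ccc(C)cc1`, > 50000 nM, a limit of the assay.
compound 2, `COc1cc(O)cc(O)c1C(=O)/C=C/c1ccc([N+](=O)[O-])cc1`, 41000 nM.
compound 3, `COc1cc(OC)c(C(=O)/C=C/c2ccc(C)cc2)c(OC)c1`, 18400 nM.

Compound 1 gives a limit of the assay rather than a number, as recorded in the limit of > 50000 nM in this assay, at which 1 of the 3 values shown sits. The change from compound 1 to compound 2 is nitro in place of methyl on an aromatic carbon, and it gave an at least 1.2-fold lower number from compound 1 to compound 2 (0.08 log units; that floor lies within the scatter). Compound 3 stands lowest of the two numbers given; compound 2 gives a higher number than compound 3. How the core of compound 3 differs from the core of compound 1 is not broken down here.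

Compound 4, `COc1cc(OC)c(C(=O)/C=C/c2ccc([N+](=O)[O-])cc2)c(OC)c1`, has not yet been measured. It differs from compound 3 by nitro in place of methyl on an aromatic carbon, the same change that was made from compound 1 to compound 2, at a place described in the same words. Because the measured instance gave only an at least 1.2-fold lower number from compound 1 to compound 2 (0.08 log units; that floor lies within the scatter), the step is expected to be small: compound 4 is estimated to give a 1.2-fold lower number from compound 3 to compound 4 (0.09 log units; within the scatter) in this assay. Compound 4 is therefore estimated at 15000 nM, expected to fall between 6000 nM and 40000 nM.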

Compound 4, half-maximal inhibitory concentration: 9400 nM
Estimate against measurement, compound 4: 1.6-fold (0.20 log units) above; the measured number falls inside the stated range.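

On the second core, in this assay, nitro in place of methyl on an aromatic carbon gave a 2.0-fold lower number from compound 3 to compound 4 (0.29 log units; within the scatter), so this step alone does not separate compound 3 from compound 4 on this read-out. Set beside the step on the first core, the change reads as follows: the same change on two cores in this assay, an at least 1.2-fold lower number (0.08 log units; that floor lies within the scatter) from compound 1 to compound 2 and a 2.0-fold lower number (0.29 log units; within the scatter) from compound 3 to compound 4; the limit leaves it open whether they differ. Compound 1 stands only at a limit of the assay, > 50000 nM, so the two cores do not show that the change has the same size on both, nor that its size differs between them.

The compounds shown carry only methyl or nitro in this place, which leaves open whether an amine, a carboxylic acid or a chlorine atom there would give a step beyond the scatter on either core. On these data alone, it also remains open how the change would read on a further core, and how the differences between the two cores would read if taken one at a time.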